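A few compounds are considered here, and "the series" means these few. Any claim that something is new, unique, unknown or untested is made for them only; others in the source may bear on it.

Of the compounds shown here, three built on one shared core have been measured in a functional assay on MDA-MB-435 cells (Homo sapiens) for inhibition, read by sulforhodamine B assay, with a stated time of 48 h; a higher number here means that more compound is tolerated, a lower number that less compound is tolerated. Compound 1 `COc1ccc(-c2cc(/C=C/C(=O)c3ccc(OC)c(OC)c3)[nH]n2)cc1` gives 8170 nM in this assay. Compound 3 `COc1ccc(-c2cc(/C=C/C(=O)c3cc(OC)c(OC)c(OC)c3)[nH]n2)cc1OC` gives 9200 nM in this assay, and compound 3 and compound 1 sit within the usual scatter of each other, so among the numbers shown compound 3 stands on the same level as compound 1. Compound 2 `COc1cc(-c2cc(/C=C/C(=O)c3ccc(Cl)c(Cl)c3)[nH]n2)cc(OC)c1OC` reaches only a limit of the assay, > 100000 nM, the case named in the limit of > 100000 nM in this assay, at which 1 of the 3 values shown sits, so no number is known for it.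

Compound 4 `COc1cc(C(=O)/C=C/c2cc(-c3cc(OC)c(OC)c(OC)c3)n[nH]2)cc(OC)c1OC` is the next step from compound 3. The change is methoxy in place of hydrogen on an aromatic carbon. Going by the values given here, no two measured compounds differ in just one place, so no measured step shows how such a change acts here. Between compound 1 and compound 3, methoxy groups were added and the two numbers stayed within the scatter, which gives no sign of a large move. The step from compound 3 to compound 4 is therefore expected to be small, a 1.3-fold higher number from compound 3 to compound 4 (0.12 log units; within the scatter), within or barely beyond the scatter. Compound 4 is estimated to give about 12000 nM in this assay, with a likely range from 4000 nM to 60000 nM.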

Compound 4, concentration lethal to 50% of the cells: 5820 nM
The estimate for compound 4 lay 2.1-fold (0.31 log units) above the measured number; measured number inside the range.
By their numbers in this assay, from the lowest: compounds 4, 1 and 3 (each within the scatter of the next). At a limit, above all of these: compound 2.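

Going by these compounds alone, the first comparison of two compounds that differ in one place is in this assay: a 1.6-fold lower number from compound 3 to compound 4 (0.20 log units; within the scatter). On this evidence, a methoxy group on this aromatic carbon, ortho to a methoxy group and meta to a large group, does not separate compound 4 from compound 3 in a way that can be told apart from repeat-measurement noise. None of the information available bears on why the numbers of this pair stay so close.

From the compounds shown here alone, what an amine or a carboxylic acid on this same aromatic carbon would do remains open, as does the effect of a longer chain such as ethoxy in place of the methoxy group. Going by these compounds, whether methoxy in place of hydrogen behaves the same way at other positions on the shared core also remains unknown.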